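A few compounds are considered here, and "the series" means these few. Any claim that something is new, unique, unknown or untested is made for them only; others in the source may bear on it.

Working notes on the series. Compound 1 `O=C1/C(=C/c2ccncc2)CN(S(=O)(=O)c2ccc(Cl)cc2)C/C1=C\c1ccccc1F` and compound 2 `N#Cc1ccc(S(=O)(=O)N2C/C(=C\c3ccncc3)C(=O)/C(=C/c3ccccc3F)C2)cc1` share one core and differ only on the sulfonyl-bearing aromatic ring. Among the compounds with values here, in a functional assay on SMMC-7721 cells (Homo sapiens) for cytotoxicity, read by MTT assay, with a stated time of 24 h (on this read-out higher numbers stand for weaker inhibition and lower numbers for stronger inhibition), compound 1 gives 9600 nM, and compound 2 gives 16200 nM; the step of a 1.7-fold higher number from compound 1 to compound 2 (0.23 log units; within the scatter) is the only measured step so far, and it does not separate the two. Compound 2 thus has the higher of the two numbers, with compound 1 within the scatter of it.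

Compound 3 `N#Cc1ccc(S(=O)(=O)N2C/C(=C\c3ccncc3)C(=O)/C(=C/c3ccccc3C(F)(F)F)C2)cc1` is the next step: trifluoromethyl in place of fluoro on an aromatic carbon. Within the data shown here, no measured step touches this position; the one step in hand concerns the sulfonyl-bearing ring and was within the scatter, so it neither supports nor opposes a shift here. The expectation is therefore a change of a 1.1-fold lower number from compound 2 to compound 3 (0.03 log units; within the scatter), in no firm direction, and compound 3 is estimated at 15000 nM in this assay, with a range from 5000 nM to 45000 nM.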

Compound 3, half-maximal inhibitory concentration: 9610 nM
The estimate for compound 3 lay 1.6-fold (0.19 log units) above the measured number, and the stated range covers the measured number.
By their numbers in this assay, from the lowest: compounds 1, 3 and 2 (each within the scatter of the next).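

Within the data shown here, the first measured step at this position is a 1.7-fold lower number from compound 2 to compound 3 (0.23 log units; within the scatter) in this assay, so 2-(trifluoromethyl)phenyl in place of 2-fluorophenyl does not separate the two compounds. On this aromatic carbon, ortho to a large group, the exchange of fluoro, with 1 heavy atom, for trifluoromethyl, with 4 heavy atoms, gives no shift that can be told from the scatter in this pair. No measurement in hand accounts for how close the two numbers lie.

Going by these compounds, it remains open whether a group of another kind on this aromatic carbon, such as an amine or a carboxylic acid, would move the number beyond the scatter. On these data alone, it is also open whether the same exchange reads alike with the chloro group of compound 1 on the sulfonyl-bearing ring.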